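A few compounds are considered here, and "the series" means these few. Any claim that something is new, unique, unknown or untested is made for them only; others in the source may bear on it.

In a functional assay on OVCAR-8 cells (Homo sapiens) (on this read-out higher numbers stand for weaker inhibition of growth and lower numbers for stronger inhibition of growth), compound 1 `O=S(=O)(/C=C/c1ccccc1)Cc1ccc(Nc2ncnc3ccccc23)cc1`, with a plain phenyl, gives > 100000 nM, and this value is a limit of the assay, not a number. Compound 2 `O=S(=O)(/C=C/c1ccc(Cl)cc1Cl)Cc1ccc(Nc2ncnc3ccccc23)cc1`, with 2,4-dichlorophenyl in its place, gives 4000 nM, and compound 3 `O=S(=O)(/C=C/c1ccc(O)cc1)Cc1ccc(Nc2ncnc3ccccc23)cc1`, with 4-hydroxyphenyl, gives 1000 nM. Compound 3 therefore holds the lowest number of the three in this assay, and compound 2 is its nearest neighbour.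

Compound 4 `O=S(=O)(/C=C/c1ccc(O)cc1)Cc1ccc(Nc2ncnc3ccc(Br)cc23)cc1` keeps the 4-hydroxyphenyl and alters the core of compound 3: bromo in place of hydrogen on an aromatic carbon. The measured steps bear on this only indirectly. They comprise an at least 25-fold lower number from compound 1 to compound 2 (1.39 log units; beyond the scatter) and an at least 100-fold lower number from compound 1 to compound 3 (2.00 log units; beyond the scatter), both large, and a 4.0-fold lower number from compound 2 to compound 3 (0.60 log units; beyond the scatter), which is modest. All three changed the group on the double-bonded chain carbon, and none changed the core, so they give no direction for the new change. The expectation thus starts from compound 3 at 1000 nM, with no step beyond the scatter as the likeliest outcome and a modest step in either direction still possible. The estimated change is a 1.3-fold lower number from compound 3 to compound 4 (0.10 log units; within the scatter). For compound 4 the expected value is 800 nM, with an estimated range from 150 nM to 5000 nM.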

Compound 4, concentration for 50% growth inhibition: > 100000 nM
Compound 4: only a limit was reported; the forecaster's own chance of this, stated with the estimate: 5%; middle value at least 120-fold (2.09 log units) from the limit.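

Bromo in place of hydrogen on an aromatic carbon of the core, meta to a fused ring and para to a fused ring, brings an at least 100-fold higher number from compound 3 to compound 4 (2.00 log units; beyond the scatter), and this is the only step shown that touches the core. Among the compounds shown here, a change of a single heavy atom there thus takes away all the measurable growth inhibition that 4-hydroxyphenyl had brought in place of plain phenyl, so the core matters in this assay at least as much as the group on the double-bonded chain carbon, which the earlier steps had varied alone. Compound 4 gives > 100000 nM, which is a limit of the assay and not a number, so the step marks only the least possible size of the loss, and compound 4 cannot be ranked against compound 1: the limit of > 100000 nM in this assay, at which 2 of the 4 values shown sit.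

On these data alone, only hydrogen and bromo appear at this carbon, so it stays open whether the loss is particular to bromo or would also follow from a fluoro, a methoxy or an amine there. As far as these compounds go, it also stays open whether bromo at this carbon would have the same outcome alongside the 2,4-dichlorophenyl of compound 2.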